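A few compounds are considered here, and "the series" means these few. Any claim that something is new, unique, unknown or untested is made for them only; others in the source may bear on it.

The measured compounds:
Compound 1, `CS(=O)(=O)N1CC(CCl)c2cc(Br)c(O)cc21`: in a functional assay on KB cells (Homo sapiens), read by crystal violet staining (on this read-out lower numbers stand for stronger inhibition and higher numbers for weaker inhibition), compound 1 gives 3.8 ug/mL.
Compound 2, `CS(=O)(=O)N1CC(CCl)c2cc([N+](=O)[O-])c(O)cc21`: in this assay compound 2 gives 8.85 ug/mL.
Compound 3, `CS(=O)(=O)OCC1CN(S(C)(=O)=O)c2cc(OCc3ccccc3)c(Br)cc21`: in this assay compound 3 gives 5.21 ug/mL.

One change recurs in this set, and it occurs twice among the compounds shown. Between compound 1 and compound 2 it is nitro in place of bromo on an aromatic carbon, and it made a 2.3-fold higher number from compound 1 to compound 2 (0.37 log units; beyond the scatter). Compound 4, `CS(=O)(=O)OCC1CN(S(C)(=O)=O)c2cc(OCc3ccccc3)c([N+](=O)[O-])cc21`, has not yet been measured; it arises from compound 3 by nitro in place of bromo on an aromatic carbon. The difference between the core of compound 1 and the core of compound 3 is not broken down here. The surroundings of the change also differ: in compound 1 the carbon that carries the bromo group is ortho to a hydroxy group, whereas in compound 3 it is ortho to a benzyloxy group, so the second change is the same kind of change as the first rather than the same change. Compound 3 and compound 1 give numbers within the scatter of each other, as do compound 3 and compound 2, so no order among the three can be read from them.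

Going by the values given here, the expectation for compound 4 rests on the single earlier step, a 2.3-fold higher number from compound 1 to compound 2 (0.37 log units; beyond the scatter), applied to the value of compound 3, 5.21 ug/mL. Compound 4 is therefore expected to give 12 ug/mL in this assay, within a range from 6 ug/mL to 25 ug/mL. Compound 4 is thus expected to show a 2.3-fold higher number from compound 3 to compound 4 (0.36 log units; beyond the scatter), a step of about the size of the earlier one, though a single precedent in a different surrounding leaves the estimate uncertain.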

Compound 4, half-maximal inhibitory concentration: 7.91 ug/mL
Compound 4: the middle estimate sits 1.5-fold (0.18 log units) above what was measured; the range from low to high includes it.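

In this assay, nitro in place of bromo on the core of compound 3, at the aromatic carbon ortho to a benzyloxy group, gave a 1.5-fold higher number from compound 3 to compound 4 (0.18 log units; within the scatter), so on this core the change cannot be told apart from the scatter, whereas on the core of compound 1 the step lay just beyond it. The two steps themselves cannot be told apart, so nothing here shows that the core alters what this change does: the same change on two cores in this assay, a 2.3-fold higher number (0.37 log units; beyond the scatter) from compound 1 to compound 2 and a 1.5-fold higher number (0.18 log units; within the scatter) from compound 3 to compound 4, 1.5-fold (0.19 log units) apart, within the scatter of two such steps. Going by these compounds alone, this fits with the change carrying over from one core to the other, but it does not show that the step has the same size on both or that it has any real effect on the core of compound 3, and with only two pairs, one of them inside the scatter, it gives no firm rule for the series.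

The compounds shown leave open how other groups would behave on this aromatic carbon, such as an amine, a nitrile or a carboxylic acid in place of bromo or nitro. Within the data shown here, they also leave open which of the several differences between the core of compound 1 and the core of compound 3 matter, since no pair here isolates any one of them.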